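Notes on thioether side chains of the shared core

The compounds below may be only part of what the source reports. "The series", "measured", "known", "first", "only" and "open" are said of these compounds alone.

Compound 1 `CCCCCCSC[C@H]1C2CC[C@@H](O2)[C@H]1C/C=C\CCCC(=O)O` carries a hexyl chain on the sulfur of the side arm. In a functional assay on a cell-free system (plasma) with thromboxane A2 receptor (Homo sapiens) as the target (on this read-out higher numbers stand for weaker inhibition and lower numbers for stronger inhibition), compound 1 gives 83000 nM. Compound 2 `O=C(O)CCC/C=C\CC1C2CCC(O2)C1CSCC1CCCCC1` replaces that chain by a cyclohexylmethyl group on the same sulfur; in this assay compound 2 gives 20000 nM. Of the two numbers, compound 2 stands at the lower one, and its gap to compound 1 is beyond the scatter of repeated measurements, so compound 2 is the stronger inhibitor of the pair.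

The next step leads to compound 3 `CCCNC(=O)CSCC1C2CCC(O2)C1C/C=C\CCCC(=O)O`, which differs from compound 2 as follows: propylcarbamoyl in place of cyclohexyl on a saturated chain carbon bound to a sulfur. For the measured compounds named here, no comparable change occurs elsewhere, so there is no measured step to lean on; the only anchor is the value of compound 2 in this assay. The expected step of a 1.3-fold lower number from compound 2 to compound 3 (0.12 log units; within the scatter) is modest, at or near the edge of the scatter, with the direction left open. Compound 3 is therefore estimated at 15000 nM, within a range from 3000 nM to 80000 nM.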

Compound 3, half-maximal inhibitory concentration: 72000 nM
Beside the measured number, compound 3's estimate is 4.8-fold (0.68 log units) below it; the range from low to high includes it.
By their numbers in this assay, from the lowest: compound 2; then compounds 3 and 1 (each within the scatter of the next).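

Exchanging cyclohexyl for propylcarbamoyl on a saturated chain carbon bound to a sulfur gives a 3.6-fold higher number from compound 2 to compound 3 (0.56 log units; beyond the scatter) in this assay, so inhibition at this position weakens beyond the scatter even though the entering group has as many heavy atoms as the one that leaves. Compound 3 at 72000 nM and compound 1 at 83000 nM lie within the scatter of each other, which leaves compound 2, the only one of the three with a ring on this side arm, apart at the lower number, and neither the hexyl chain nor the propylcarbamoyl group matches it. Nothing at hand bears on what lies behind this step.

The step removes the ring and brings in the hydrogen-bond donor and acceptor at once, so the share of each in the weaker inhibition stays unresolved. A phenyl group on the same carbon would test the ring with no propylcarbamoyl present, and a cyclohexylcarbamoyl group would test the carbamoyl unit with the ring kept in place.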